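The compounds below may be only part of what the source reports. "The series", "measured", "known", "first", "only" and "open" are said of these compounds alone.

Compound 3, with the structure `C=CCn1c(=O)/c(=C\c2cccc(Cl)c2Cl)[nH]c(=O)/c1=C\c1ccccc1OC`, was tested in a functional assay on U-937 cells (Homo sapiens) for cytotoxicity, read by CCK-8 assay, with a stated time of 72 h (on this read-out higher numbers stand for weaker inhibition and lower numbers for stronger inhibition), where it gives 500 nM. Two related compounds frame it. Compound 1, with the structure `COc1ccccc1/C=c1/[nH]c(=O)/c(=C\c2ccccc2OC)n(C)c1=O`, carries a methyl on the ring nitrogen and two methoxyphenyl arms; in this assay compound 1 gives 1500 nM, a higher number than compound 3, and that gap lies beyond the usual scatter of repeated runs. Compound 2, with the structure `COc1ccccc1/C=c1/[nH]c(=O)/c(=C\c2cccc(Cl)c2Cl)[nH]c1=O`, carries no group at all on that nitrogen and the dichlorophenyl arm; in this assay compound 2 was reported as "not active" (no number reported), with no single number. So among the numbers at hand, compound 3 holds the lowest one.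

Compound 4, with the structure `COc1ccccc1/C=c1\c(=O)[nH]/c(=C/c2cccc(Cl)c2Cl)c(=O)n1C`, differs from compound 3 by one cut: hydrogen in place of vinyl on a saturated chain carbon bound to an aromatic nitrogen, so that the allyl chain of compound 3 becomes a methyl. Within the data shown here, no measured pair here shows this exact change, so its size must be guessed. Compound 1, which also carries a methyl on that nitrogen, gives 1500 nM, while compound 2, with no group there, gives no number, which leaves the direction open. For compound 4 in this assay the expected step of a 2.0-fold higher number from compound 3 to compound 4 (0.30 log units; within the scatter) is a mild weakening, with an estimate of 1000 nM and a likely range from 300 nM to 3500 nM.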

Compound 4, half-maximal inhibitory concentration: 100 nM
Compound 4: the middle estimate sits 10-fold (1.00 log units) above what was measured, and the stated range ends above it.
By their numbers in this assay, from the lowest: compound 4; then compound 3; then compound 1.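

In this assay, replacing the allyl chain on the ring nitrogen with a methyl gives a 5.0-fold lower number from compound 3 to compound 4 (0.70 log units; beyond the scatter) in a direct comparison, so this position responds to the group it carries, and here the smaller of the two groups goes with the lower number. Compound 2, with only hydrogen on that nitrogen, was reported as "not active", so among these three compounds the methyl gives the lowest number and a group on the nitrogen goes with a measurable value. With the methyl held fixed, 2,3-dichlorophenyl in place of 2-methoxyphenyl gives a 15-fold lower number from compound 1 to compound 4 (1.18 log units; beyond the scatter) as a second clear step, showing that the arm also shapes the result, while no supporting data explain either step.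

The compounds shown leave open whether the trend from allyl to methyl continues through an ethyl or propyl chain, or whether a chain ending in an amine or a carboxylic acid would be tolerated on that nitrogen. They also leave open whether the arm change would give a similar step with the allyl chain in place of the methyl.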